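A few compounds are considered here, and "the series" means these few. Any claim that something is new, unique, unknown or untested is made for them only; others in the source may bear on it.

Compound 1 `COc1cc(C(=O)NNC(=S)Nc2csc(-c3ccccc3)c2)cc(OC)c1OC` gives 32000 nM in a functional assay on B16-F10 cells (Mus musculus) for inhibition, read by colorimetric assay and MTT assay, with a stated time of 72 h; on this read-out higher numbers stand for weaker inhibition and lower numbers for stronger inhibition. Compound 2 `COc1cc(C(=O)NNC(=S)Nc2csc(-c3ccc(C)cc3)c2)cc(OC)c1OC` gives 13000 nM in this assay. Compound 3 `COc1ccc(C(=O)NNC(=S)Nc2csc(-c3ccccc3)c2)cc1` gives 33000 nM in this assay.

Compound 4 `COc1ccc(C(=O)NNC(=S)Nc2csc(-c3ccc(C)cc3)c2)cc1` has not yet been measured in this assay. It differs from compound 3 only by methyl in place of hydrogen on an aromatic carbon. The same change separates compound 1 from compound 2, namely (methyl in place of hydrogen on an aromatic carbon), and there it produced a 2.5-fold lower number from compound 1 to compound 2 (0.39 log units; beyond the scatter). How the core of compound 3 differs from the core of compound 1 is not broken down here; the two compounds give numbers within the usual scatter of each other. Since the change is the same in kind and in place, the estimate rests on the earlier step of a 2.5-fold lower number from compound 1 to compound 2 (0.39 log units; beyond the scatter), and a step of similar size is expected, a 2.4-fold lower number from compound 3 to compound 4 (0.37 log units; beyond the scatter). Compound 4 is therefore expected to give about 14000 nM, most likely between 6000 nM and 33000 nM.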

Compound 4, half-maximal inhibitory concentration: 9000 nM
For compound 4 the middle estimate is 1.6-fold (0.19 log units) above the measured one; measured number inside the range.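

In this assay, changing phenyl to 4-methylphenyl gives a 3.7-fold lower number from compound 3 to compound 4 (0.56 log units; beyond the scatter), so the number falls on this core as it did on the core of compound 1. The direction is shared, and the two steps cannot be told apart in size: the same change on two cores in this assay, a 2.5-fold lower number (0.39 log units; beyond the scatter) from compound 1 to compound 2 and a 3.7-fold lower number (0.56 log units; beyond the scatter) from compound 3 to compound 4, 1.5-fold (0.17 log units) apart, within the scatter of two such steps. For the compounds shown here, this rests on only two pairs in one cell assay, so it shows that the change carried over once, not that it would do so on any other core, and it does not explain why the number falls.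

The compounds shown leave open what a different group in the same place would do, such as an ethyl, a chlorine or an amine. They also leave open whether a longer chain would lower the number further or raise it.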